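From Butyl to Isopropoxy: Estimating Compound 3

The source may report more compounds than this note shows. Statements on the series, on what has been measured and on what is new or still open speak of the compounds shown alone.

Measured compounds:
compound 1, `CCCCOC(=O)NS(=O)(=O)c1ccc(CC(C)C)cc1-c1ccc(Cn2ccnc2)cc1`: > 10000 nM
compound 2, `CCCCOC(=O)NS(=O)(=O)c1ccc(CCCC)cc1-c1ccc(Cn2ccnc2)cc1`: > 10000 nM

In an assay on membranes from liver for displacement of a labelled ligand from Type-2 angiotensin II receptor (Rattus norvegicus) (a lower number here means a stronger inhibitor, a higher number a weaker inhibitor), compound 1 gives > 10000 nM, which is a limit of the assay and not a number. Compound 2 gives > 10000 nM, also a limit. The step that the two limits leave unreadable from compound 1 to compound 2 therefore cannot be read. Compound 2 thus stands at the limit of > 10000 nM in this assay, at which 2 of the 2 values shown sit, with no numerical value to build on.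

Compound 3, `CCCCOC(=O)NS(=O)(=O)c1ccc(OC(C)C)cc1-c1ccc(Cn2ccnc2)cc1`, differs from compound 2 by isopropoxy in place of butyl on an aromatic carbon. Within the data shown here, no measured step bears on this change, since the only step between measured compounds, a step that the two limits leave unreadable from compound 1 to compound 2, is unreadable, and so no direction and no size beyond the scatter can be expected from the data.

With both neighbours at the limit, compound 3 is expected to give 10000 nM in this assay, within a range of 3000 nM to 30000 nM. This estimate means an expected step of a number no higher from compound 2 to compound 3 (the limit leaves the size open), and most likely the assay will again report only a limit.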

Compound 3, inhibition constant: > 10000 nM
Compound 3: a limit, no number; the forecaster's own chance of this, stated with the estimate: 75%; the middle value lies on the limit itself.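

Compound 1, compound 2 and compound 3 all sit at a limit of the assay and not at a number, so no step among them can be read: the limit of > 10000 nM in this assay, at which 3 of the 3 values shown sit.

From the compounds shown here alone, how strongly each of them binds in this assay stays open, as does whether isopropoxy and butyl differ at all.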